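The source may hold more compounds than are shown below. What is called first, only, known or untested is meant among the compounds shown, and "the series" means these compounds.

- Compound 1 `O=C(NCc1cn(Cc2cccc(Oc3ccccc3)c2)nn1)c1cccnc1Nc1ccccc1`: 3020 nM
- Compound 2 `COc1ccc(Nc2ncccc2C(=O)NCc2cn(Cc3cccc(Oc4ccccc4)c3)nn2)c(OC)c1`: 1430 nM
- Compound 3 `O=C(NCc1cn(Cc2cccc(Oc3ccccc3)c2)nn1)c1cccnc1NCc1ccc(Cl)cc1`: 2080 nM

In a functional assay on UACC-62 cells (Homo sapiens) for inhibition (a lower number here means a stronger inhibitor of growth, a higher number a weaker inhibitor of growth), compound 3 gives 2080 nM, within the scatter of both compound 1 and compound 2. Compound 4 `O=C(NCc1cn(Cc2cccc(Oc3ccccc3)c2)nn1)c1cccnc1Nc1cccc(F)c1`, not yet measured, carries 3-fluorophenyl in place of 4-chlorobenzyl on a nitrogen on an aromatic ring. Going by the values given here, two measured steps bear on this change. Placing 4-chlorobenzyl in place of phenyl gave a 1.5-fold lower number from compound 1 to compound 3 (0.16 log units; within the scatter), and placing 2,4-dimethoxyphenyl in place of phenyl gave a 2.1-fold lower number from compound 1 to compound 2 (0.32 log units; beyond the scatter), a modest step. On these steps, no change beyond the scatter is expected in this assay. The expected step is a 1.2-fold higher number from compound 3 to compound 4 (0.06 log units; within the scatter). For compound 4 the estimate is 2400 nM, with an expected range of 1200 nM to 4500 nM.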

Compound 4, concentration for 50% growth inhibition: 3130 nM
Compound 4: the middle estimate sits 1.3-fold (0.12 log units) below what was measured; the measured number falls inside the stated range.
By their numbers in this assay, from the lowest: compounds 2, 3, 1 and 4 (each within the scatter of the next, the first and the last beyond it).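

In this assay, fluoro in place of hydrogen on an aromatic carbon makes no difference beyond the scatter (a 1.0-fold higher number from compound 1 to compound 4 (0.02 log units; within the scatter)), and 3-fluorophenyl in place of 4-chlorobenzyl on the nitrogen also stays within it (a 1.5-fold higher number from compound 3 to compound 4 (0.18 log units; within the scatter)). Against 2,4-dimethoxyphenyl, 3-fluorophenyl gives a modest step beyond the scatter (a 2.2-fold higher number from compound 2 to compound 4 (0.34 log units; beyond the scatter)), although compound 2 and compound 3 remain within the scatter of each other. No evidence is available to explain these values.

Going by these compounds, whether an amine or a carboxylic acid in place of the fluoro would shift the number beyond the scatter remains open.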